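The source may report more compounds than this note shows. Statements on the series, on what has been measured and on what is new or still open speak of the compounds shown alone.

In a functional assay on PC-3 cells (Homo sapiens) for inhibition, read by CellTiter-Glo, with a stated time of 72 h (on this read-out higher numbers stand for lower toxicity in this test and lower numbers for higher toxicity in this test), two compounds sharing a core have been tested so far. Compound 1 (`CC1=C(CC(=O)N2CCN(CCCN(C)C)CC2)c2cc(F)ccc2/C1=C\c1ccc([S+](C)[O-])cc1`) gives > 50000 nM, which is a limit of the assay and not a number. Compound 2 (`CC1=C(CC(=O)N(C)CCN(C)C(=O)[C@@H](N)C(C)C)c2cc(F)ccc2/C1=C\c1ccc([S+](C)[O-])cc1`) gives > 50000 nM, which is also a limit, so it has no exact value. The whole picture so far is the limit of > 50000 nM in this assay, at which 2 of the 2 values shown sit.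

Compound 3 (`CC1=C(CC(=O)N(C)CCN(C)S(C)(=O)=O)c2cc(F)ccc2/C1=C\c1ccc([S+](C)[O-])cc1`) has methylsulfonyl in place of (1-amino-2-methylpropyl)carbonyl on an amine nitrogen, and the count of that change from compound 2 is methylsulfonyl in place of (1-amino-2-methylpropyl)carbonyl on an amine nitrogen. Among the compounds with values here, no measured pair shows what this swap does. Any expectation therefore rests on compound 2, which shows > 50000 nM. The expected result is a number no higher from compound 2 to compound 3 (the limit leaves the size open), meaning no change beyond the usual scatter. For compound 3 the estimated value is 50000 nM, with an expected range from 20000 nM to 100000 nM.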

Compound 3, half-maximal cytotoxic concentration: 42600 nM
Estimate against measurement, compound 3: 1.2-fold (0.07 log units) above; measured number inside the range.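

In this assay, within the data shown here, compound 3 gives 42600 nM, the only exact number among the three compounds, so this core can produce a measurable reading in this test. Putting methylsulfonyl in place of (1-amino-2-methylpropyl)carbonyl on the amine nitrogen gives an at least 1.1-fold lower number from compound 2 to compound 3 (0.06 log units; that floor lies within the scatter), and the wider change on the carbonyl carbon, methyl(2-(methyl(methylsulfonyl)amino)ethyl)amino in place of 4-(3-(dimethylamino)propyl)piperazin-1-yl, gives an at least 1.1-fold lower number from compound 1 to compound 3 (0.06 log units; that floor lies within the scatter). Both steps start from a limit and not from a number, so their true size stays open, and the other two readings remain limits: the limit of > 50000 nM in this assay, at which 2 of the 3 values shown sit.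

The compounds shown leave open how an acetyl or an ethylsulfonyl group on that amine nitrogen would read in this assay. From the compounds shown here alone, it also stays open whether any group there can move the number beyond the usual scatter.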